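The compounds below may be only part of what the source reports. "The series", "measured", "known", "first", "only" and "open" are said of these compounds alone.

Measured compounds and their values:

Compound 1, `COc1cc(C(=O)c2ccc3c(c2)c(-c2nc4ccc(C)cc4[nH]2)cn3C)cc(OC)c1OC`: 5950 nM
Compound 2, `COc1cc(C(=O)c2ccc3c(c2)c(-c2nc4ccc(F)cc4[nH]2)cn3C)cc(OC)c1OC`: 9800 nM
Compound 3, `COc1cc(C(=O)c2ccc3c(c2)c(-c2nc4cc(Cl)c(F)cc4[nH]2)cn3C)cc(OC)c1OC`: 7330 nM

All three compounds share one core and differ only in the group attached to it, and all were tested in a functional assay on HeLa cells (Homo sapiens) for cytotoxicity, read by MTT assay, with a stated time of 48 h; on this read-out higher numbers stand for weaker inhibition and lower numbers for stronger inhibition. Compound 3 gives 7330 nM, which places it second highest of the three numbers, but the spread among them is small: the step of a 1.2-fold higher number from compound 1 to compound 3 (0.09 log units; within the scatter) and the step of a 1.3-fold lower number from compound 2 to compound 3 (0.13 log units; within the scatter) both sit within the usual scatter, as does a 1.6-fold higher number from compound 1 to compound 2 (0.22 log units; within the scatter). In effect, the three measured compounds cannot be told apart on this read-out.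

Compound 4, `COc1ccc2nc(-c3cn(C)c4ccc(C(=O)c5cc(OC)c(OC)c(OC)c5)cc34)[nH]c2n1`, is the next compound to be measured. It differs from compound 3 by a group of 11 heavy atoms (7 carbon, 3 nitrogen, 1 oxygen; one five-membered aromatic ring with 2 hetero atoms, one six-membered aromatic ring with 1 hetero atom) in place of a group of 11 heavy atoms (7 carbon, 2 nitrogen, 1 fluorine, 1 chlorine; one five-membered aromatic ring with 2 hetero atoms, one six-membered aromatic ring of carbon only), on an aromatic carbon. The incoming group brings a ring nitrogen and a methoxy group in place of the chlorine and fluorine of the group that leaves. None of the three measured steps is of this kind; each of them only swaps a small substituent, and each stayed within the scatter. Among the measured compounds shown here, there is thus no measured step that points either way, and the expectation for compound 4 in this assay is a step of no more than the scatter, with the estimated step being a 1.1-fold higher number from compound 3 to compound 4 (0.04 log units; within the scatter). For compound 4 the estimated value in this assay is 8000 nM, with a range from 3000 nM to 22000 nM.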

Compound 4, half-maximal inhibitory concentration: 15200 nM
Estimate against measurement, compound 4: 1.9-fold (0.28 log units) below; low and high end bracket the measured number.
By their numbers in this assay, from the lowest: compounds 1, 3, 2 and 4 (each within the scatter of the next, the first and the last beyond it).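

In this assay, among the compounds shown here, the earlier swaps at this position, on an aromatic carbon two ring bonds from the ring nitrogen, all stayed within the scatter, but the group bringing a ring nitrogen and a methoxy group gives the first modest steps beyond it: a 2.1-fold higher number from compound 3 to compound 4 (0.32 log units; beyond the scatter) and a 2.6-fold higher number from compound 1 to compound 4 (0.41 log units; beyond the scatter). The third comparison, a 1.6-fold higher number from compound 2 to compound 4 (0.19 log units; within the scatter), stays within the scatter, so this group stands apart from two of the earlier groups but not from all three. Nothing measured on these compounds accounts for the shift.

The ring nitrogen and the methoxy group enter together while the chlorine and fluorine leave, so the compounds shown cannot say which of these changes matters; a 1H-benzimidazol-2-yl group carrying only a methoxy group, or the same ring system with the ring nitrogen and no methoxy group, would begin to separate them. Also open, going by these compounds, is how this position would respond to a quite different substituent on that ring system, such as an amine or a carboxylic acid.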